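The source may hold more compounds than are shown below. What is called first, only, known or untested is meant among the compounds shown, and "the series" means these compounds.

compound 1 `CCCCCCNC(=O)/C=C/c1ccccc1`: 55%
compound 2 `CCCCCCCCCCNC(=O)/C=C/c1ccccc1`: 10%
compound 3 `CC(C)(C)NC(=O)/C=C/c1ccccc1`: 34%

In a functional assay on the whole organism for inhibition, with Brassica rapa subsp. chinensis as the target, with a stated time of 3 days, tested at 100 ppm (on this read-out lower numbers stand for less inhibition of growth and higher numbers for more inhibition of growth at the one concentration tested), compound 3 gives 34% and stands second highest of the three, with compound 1 above it and compound 2 below it, both by more than the usual scatter. Compound 4 `CCCNC(=O)/C=C/c1ccccc1` carries propyl in place of tert-butyl on an amide-type nitrogen. Among the measured compounds shown here, no measured step makes this exact swap. For the measured compounds named here, the closest evidence is the one step that alters the chain on that nitrogen, a number 45 percentage points lower from compound 1 to compound 2 (beyond the scatter) (large), so the group there can clearly matter. That step lengthens a chain rather than replacing a branched group with a straight one, so it shows how far the read-out can move but gives no firm direction here. A small rise is expected, probably not beyond the scatter: the expected step is a number 6 percentage points higher from compound 3 to compound 4 (within the scatter) in this assay (an estimate only). For compound 4 the estimated value is 40% (expected range 20% to 60%).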

Compound 4, percent growth inhibition at one concentration: 15%
Estimate against measurement, compound 4: 25 percentage points above; measured number outside the range, below it.
By their numbers in this assay, from the lowest: compounds 2 and 4 (each within the scatter of the next); then compound 3; then compound 1.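

In this assay, the straight chains on the amide-type nitrogen now show a rise and a fall, not a simple loss with length. With a number 40 percentage points lower from compound 1 to compound 4 (beyond the scatter) the hexyl and propyl chains stand apart. The propyl and decyl compounds cannot be told apart, a number 5 percentage points higher from compound 2 to compound 4 (within the scatter). The swap itself also counts, with a number 19 percentage points lower from compound 3 to compound 4 (beyond the scatter), so branched tert-butyl holds a higher number here than straight propyl, though still a lower one than the hexyl chain of compound 1. Nothing available explains why these groups differ.

Still open, as far as these compounds go, is whether a butyl, pentyl, heptyl or octyl chain would match or pass compound 1, which would show how narrow the best length is. Also open, from the compounds shown here alone, is how a hexyl chain ending in an amine or a carboxylic acid would behave.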